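Replacing a Ring Hydrogen with Trifluoromethyl in a Hydrazone Series

The compounds below may be only part of what the source reports. "The series", "measured", "known", "first", "only" and "open" are said of these compounds alone.

Compound 1 `O=C(N/N=C/c1cc(I)cc(I)c1O)c1ccccc1` shares its core with two measured relatives, compound 2 `CC(C)(C)c1ccc(C(=O)N/N=C/c2cc(I)cc(I)c2O)cc1` and compound 3 `O=C(N/N=C/c1cc(I)cc(I)c1O)c1ccc(Br)cc1`. In a functional assay on HepG2 cells (Homo sapiens) for cytotoxicity, with a stated time of 24 h (on this read-out higher numbers stand for weaker inhibition and lower numbers for stronger inhibition), compound 1 reports only the limit > 50000 nM, so its true number is not pinned down. Compound 2 gives 41600 nM in this assay, and compound 3 gives 22300 nM. The move an at least 1.2-fold lower number from compound 1 to compound 2 (0.07 log units; that floor lies within the scatter) stays within the scatter, whereas an at least 2.2-fold lower number from compound 1 to compound 3 (0.35 log units; beyond the scatter) is a modest change; the pair a 1.9-fold lower number from compound 2 to compound 3 (0.27 log units; within the scatter) lies within the scatter.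

Compound 4 `O=C(N/N=C/c1cc(I)cc(I)c1O)c1ccc(C(F)(F)F)cc1` is not yet measured. It differs from compound 1 as follows: trifluoromethyl in place of hydrogen on an aromatic carbon. This is the same kind of change as in those two steps, a new group entering on an aromatic carbon of a six-membered aromatic ring of carbon only, where a hydrogen stood. Both measured steps went to lower numbers, so a lower number for compound 4 is expected, at the modest size seen for compound 3, with the step of an at least 1.6-fold lower number from compound 1 to compound 4 (0.22 log units; that floor lies within the scatter) as the estimate. In this assay compound 4 is therefore expected at 30000 nM, within 12000 nM to 80000 nM.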

Compound 4, half-maximal inhibitory concentration: 11700 nM
Compound 4: the middle estimate sits 2.6-fold (0.41 log units) above what was measured; the measured number lies below the stated range.
By their numbers in this assay, from the lowest: compounds 4, 3 and 2 (each within the scatter of the next, the first and the last beyond it). At a limit, above all of these: compound 1.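

In this assay, the trifluoromethyl change gives an at least 4.2-fold lower number from compound 1 to compound 4 (0.63 log units; beyond the scatter) and so adds a third group at this place, para to a large group, that moves to a lower number; its floor lies beyond the scatter, as does that of bromo but not that of tert-butyl. The choice of group at this place can matter, as a 3.6-fold lower number from compound 2 to compound 4 (0.55 log units; beyond the scatter) shows, whereas a 1.9-fold lower number from compound 3 to compound 4 (0.28 log units; within the scatter) leaves trifluoromethyl and bromo unseparated. Going by these compounds, the true size of the step from compound 1 stays unknown, and it can be read only as a floor because compound 1 reports a limit and not a number: the limit of > 50000 nM in this assay, at which 1 of the 4 values shown sits.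

On these data alone, how an amine, a carboxylic acid or a longer chain would behave at this place remains open. The compounds shown also leave open why these groups differ, as they offer no measured property to explain it.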